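A few compounds are considered here, and "the series" means these few. Any claim that something is new, unique, unknown or untested is made for them only; others in the source may bear on it.

Within the data shown here, compound 1 `CN1CCC(n2cc(S(=O)(=O)c3cccc(F)c3)c3cccnc32)C1` is one of two compounds measured in a functional assay on HeLa cells for agonist activity at 5-hydroxytryptamine receptor 6 (Homo sapiens), read by cAMP accumulation and immunoassay; on this read-out higher numbers stand for an effect only at larger amounts of compound and lower numbers for an effect already at smaller amounts. In this assay compound 1 gives 231 nM, the higher of the two numbers. The other measured compound, compound 2 `O=S(=O)(C1=C(Cl)NC2SC=CN12)c1cn(C2CCNC2)c2ncccc12`, gives 80 nM, and the gap between these two values lies beyond the usual scatter; since compound 2 differs from compound 1 in more than one place, no single cause can be read out of that gap.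

The unmeasured compound 3 `O=S(=O)(c1cccc(F)c1)c1cn(C2CCCNC2)c2ncccc12` differs from compound 1 in one place: piperidin-3-yl in place of 1-methylpyrrolidin-3-yl on an aromatic nitrogen. The ring that enters is one atom larger and carries a hydrogen-bond donor that the leaving group lacks, while the count of heavy atoms stays the same. Among the measured compounds shown here, no measured pair shows exactly this change, so the expected step rests on general experience with related amines rather than on a direct comparison. The expectation is a modest step toward a lower number, of a size a 1.9-fold lower number from compound 1 to compound 3 (0.28 log units; within the scatter) that stays close to the scatter. Compound 3 is therefore estimated at 120 nM, with a likely range from 40 nM to 400 nM.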

Compound 3, half-maximal effective concentration: 67 nM
The estimate for compound 3 lay 1.8-fold (0.25 log units) above the measured number; the range from low to high includes it.
By their numbers in this assay, from the lowest: compounds 3 and 2 (each within the scatter of the next); then compound 1.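

In this assay, among these compounds, putting piperidin-3-yl in place of 1-methylpyrrolidin-3-yl on the aromatic nitrogen gives a 3.4-fold lower number from compound 1 to compound 3 (0.54 log units; beyond the scatter), the first step here that can be traced to a single place in the molecule. The heavy-atom count stays the same, yet the change does two things at once: a five-membered ring becomes a six-membered ring, and the entering group has a hydrogen-bond donor that the leaving group lacks. No measurement is available to explain why the number falls.

The compounds shown leave open which of these two differences matters, and 1-methylpiperidin-3-yl at this position would help separate them, since it combines the six-membered ring with the methyl group on the ring nitrogen and has no hydrogen-bond donor. Also open, as far as these compounds go, is whether piperidin-4-yl, which joins the core through a different ring atom, would keep a number as low as that of compound 3.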